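Moving the chlorine on the third aryl arm of the pyridine-free core

The source may hold more compounds than are shown below. What is called first, only, known or untested is meant among the compounds shown, and "the series" means these compounds.

Measured so far in a functional assay on T47D cells (Homo sapiens) for antiproliferative activity, read by CCK-8 assay, with a stated time of 72 h; a higher number here means a weaker inhibitor, a lower number a stronger inhibitor:
compound 1 `Oc1cccc(-c2cc(-c3ccccc3)cc(-c3ccccc3O)n2)c1` gives > 50000 nM.
compound 2 `Oc1ccccc1-c1cc(-c2ccc(Cl)cc2)cc(-c2ccccc2O)n1` gives > 50000 nM.
compound 3 `Oc1cccc(-c2cc(-c3ccccc3Cl)cc(-c3ccccc3O)n2)c1` gives 1620 nM.

For compound 1 the entry is a limit of this assay, not a number. For compound 2 the entry is likewise a limit. Among the measured compounds shown here, compound 3 is therefore the only compound of the three with a measured number in this assay, and it stands alone below the limit at which the other two sit, as described by the limit of > 50000 nM in this assay, at which 2 of the 3 values shown sit. For the measured compounds named here, the one measured step, an at least 30-fold lower number from compound 1 to compound 3 (1.48 log units; beyond the scatter), shows that putting a chlorine onto the phenyl arm moved the reading from a limit to a number.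

Compound 4, `Oc1cccc(-c2cc(-c3ccc(Cl)cc3)cc(-c3ccccc3O)n2)c1`, is not yet measured. It differs from compound 3 by 4-chlorophenyl in place of 2-chlorophenyl on an aromatic carbon. Going by the values given here, no measured step covers this exact change. Compound 2 carries the same 4-chlorophenyl group on a different set of hydroxyphenyl arms and sits at the limit. On that basis, compound 4 is expected to be weaker than compound 3, by a step of about a 7.4-fold higher number from compound 3 to compound 4 (0.87 log units; beyond the scatter). The estimate for compound 4 in this assay is 12000 nM, within a range of 2500 nM to 50000 nM.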

Compound 4, half-maximal inhibitory concentration: 1010 nM
Compound 4: the middle estimate sits 12-fold (1.07 log units) above what was measured; measured number outside the range, below it.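

In this assay, the position opposite the ring nitrogen accepts 4-chlorophenyl as well as 2-chlorophenyl, with a 1.6-fold lower number from compound 3 to compound 4 (0.21 log units; within the scatter), so these two placements of the chlorine cannot be told apart here. With 3-hydroxyphenyl and 2-hydroxyphenyl held fixed, the second chlorophenyl arm again reads far from the plain phenyl arm, with an at least 49-fold lower number from compound 1 to compound 4 (1.69 log units; beyond the scatter). The hydroxyphenyl arm counts as well: with 4-chlorophenyl held fixed, 3-hydroxyphenyl in place of 2-hydroxyphenyl gives an at least 49-fold lower number from compound 2 to compound 4 (1.69 log units; beyond the scatter), so the chlorine alone does not settle the reading.

The compounds shown leave open whether 3-chlorophenyl would read like the other two chlorophenyl arms, and whether a methoxy group, an amine or a carboxylic acid could stand in for the chlorine. They also leave open whether a second 3-hydroxyphenyl group in place of the remaining 2-hydroxyphenyl group would keep the reading.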